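This account rests on a few compounds, and the source may have more. Where it says the series, first, only, none or still open, it means among the compounds named here.

Compound 1 `Cc1nc(S(C)(=O)=O)ccc1Oc1ncnc(OC2CCN(C(=O)O[C@H](C)C(F)(F)F)CC2)c1F`: 110 nM
Compound 2 `CCC1(OC(=O)N2CCC(Oc3ncnc(Oc4ccc(S(C)(=O)=O)nc4C)c3F)CC2)CC1`: 333 nM
Compound 3 `Cc1nc(S(C)(=O)=O)ccc1Oc1ncnc(OC2CCN(C(=S)OC(C)C)CC2)c1F`: 1050 nM

The three measured compounds share one core and differ only in the group carried on the amine nitrogen in the ring. In a functional assay on isolated protein for inhibition of Glucose-dependent insulinotropic receptor (Rattus norvegicus), read by HTRF and cAMP accumulation (a higher number here means that more compound is needed for the effect, a lower number that less compound is needed), compound 2 stands second highest of the three numbers; its nearest neighbour is compound 1, with a 3.0-fold higher number from compound 1 to compound 2 (0.48 log units; beyond the scatter), and its furthest is compound 3, with a 3.2-fold higher number from compound 2 to compound 3 (0.50 log units; beyond the scatter). Compound 4 `Cc1nc(S(C)(=O)=O)ccc1Oc1ncnc(OC2CCN(C(=O)C3(F)CCC3)CC2)c1F` has not yet been measured. It differs from compound 2 as follows: a group of 5 heavy atoms (4 carbon, 1 fluorine; one four-membered non-aromatic ring of carbon only) in place of a group of 6 heavy atoms (5 carbon, 1 oxygen; one three-membered non-aromatic ring of carbon only), on a carbonyl carbon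

Going by the values given here, no measured step makes exactly this kind of exchange on a carbonyl carbon, so the available steps bear on it only indirectly. Swapping one group on the oxygen of the carbamate for another, as in a 3.0-fold higher number from compound 1 to compound 2 (0.48 log units; beyond the scatter), gave a modest shift, and swapping the whole group on the ring nitrogen, as in a 9.5-fold higher number from compound 1 to compound 3 (0.98 log units; beyond the scatter), gave a larger but still modest one. The data therefore suggest that changes at this position move the number by modest amounts, but they do not fix the direction. Compound 4 is expected to give about 300 nM in this assay, within a range of 100 nM to 1000 nM, which corresponds to an expected step of a 1.1-fold lower number from compound 2 to compound 4 (0.05 log units; within the scatter).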

Compound 4, half-maximal effective concentration: 123 nM
For compound 4 the middle estimate is 2.4-fold (0.39 log units) above the measured one; the measured number falls inside the stated range.
By their numbers in this assay, from the lowest: compounds 1 and 4 (each within the scatter of the next); then compound 2; then compound 3.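

In this assay, the group with one four-membered non-aromatic ring of carbon only and a fluorine enters on the carbonyl carbon in place of the group with one three-membered non-aromatic ring of carbon only and an oxygen, and the result is a 2.7-fold lower number from compound 2 to compound 4 (0.43 log units; beyond the scatter), the first step shown in which the group on this carbonyl carbon holds no oxygen. Set against the carbamate carrying the 1-(trifluoromethyl)ethyl group, the same position gives a 1.1-fold higher number from compound 1 to compound 4 (0.05 log units; within the scatter) and the two do not separate, so among these compounds a group without that oxygen does as well as the best carbamate. The exchange also reaches well past the sulfur-bearing group on the ring nitrogen, with an 8.5-fold lower number from compound 3 to compound 4 (0.93 log units; beyond the scatter) as the step, which shows that the carbonyl with this fluorinated ring sits at the low end of the numbers seen here.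

Nothing measured on these compounds accounts for these shifts. From the compounds shown here alone, whether the fluorine, the ring size or the lost oxygen carries the step stays open, as does how a cyclobutyl group without the fluorine or an amine on the carbonyl carbon would read in this assay.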